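The compounds below may be only part of what the source reports. "The series", "measured", "known", "first", "only" and "open" are said of these compounds alone.

Of the compounds shown here, two with a shared core have been tested in a functional assay on MIA PaCa-2 cells (Homo sapiens) for inhibition, read by MTT assay; on this read-out lower numbers stand for stronger inhibition and higher numbers for weaker inhibition. In this assay, compound 1 `CN(C)C(=O)c1cc2cnc(Nc3cccnc3)nc2n1C1CCCC1` gives 26000 nM. Compound 2 `O=C(Nc1ccc[n+]([O-])c1)c1cc2cnc(Nc3ccc(N4CCNCC4)cn3)nc2n1C1CCCC1` gives 125000 nM, the higher of the two numbers and so the weaker inhibition, and its gap to compound 1 lies beyond the usual scatter. Compound 3 `COc1ccc(NC(=O)c2cc3cnc(Nc4ccc(N5CCNCC5)cn4)nc3n2C2CCCC2)c(OC)c1` has not yet been measured. It differs from compound 2 only on the amide-type nitrogen: a group of 10 heavy atoms (8 carbon, 2 oxygen; one six-membered aromatic ring of carbon only) in place of a group of 7 heavy atoms (5 carbon, 1 nitrogen, 1 oxygen; one six-membered aromatic ring with 1 hetero atom), on an amide-type nitrogen. The entering 2,4-dimethoxyphenyl has a six-membered aromatic ring of carbon only, whereas the group that leaves has a ring with 1 hetero atom. Going by the values given here, no measured pair of compounds differing in one place shows what such a change does in this assay, so any forecast is uncertain. Among the compounds with values here, with compound 2 at 125000 nM, the top of the two numbers so far, a moderate move towards lower numbers, beyond the scatter, is expected rather than a further rise. The expected step is a 6.3-fold lower number from compound 2 to compound 3 (0.80 log units; beyond the scatter). The estimated value for compound 3 is 20000 nM, within an expected range of 4000 nM to 80000 nM.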

Compound 3, half-maximal inhibitory concentration: 2230 nM
Compound 3: middle estimate off by 9.0-fold (0.95 log units), on the high side; measured number below the stated range.
By their numbers in this assay, from the lowest: compound 3; then compound 1; then compound 2.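

Going by these compounds alone, compound 2 and compound 3 are the first pair that differ in one place, and they show that the group on the amide-type nitrogen can strongly shift the number in this assay: 2,4-dimethoxyphenyl entering for the group with a six-membered aromatic ring with 1 hetero atom gives a 56-fold lower number from compound 2 to compound 3 (1.75 log units; beyond the scatter). The rest of the structure is the same in both compounds, so this large step belongs to that exchange alone and shows that this position is far from indifferent on this read-out. Nothing at hand explains why the exchange has so large an effect.

The exchange alters several features at once, replacing the hetero atom in the ring with carbon and adding the methoxy groups, and this one pair cannot separate their contributions. From the compounds shown here alone, it remains open whether a plain phenyl on this nitrogen would give a number close to that of compound 3 or of compound 2, and what a phenyl with a single methoxy group, or a chain ending in an amine, would do at the same place.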